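The source may report more compounds than this note shows. Statements on the series, on what has been measured and on what is new or still open speak of the compounds shown alone.

Of the compounds shown here, two have so far been tested in an ADME assay on RD cells (Homo sapiens) for cytotoxicity, read by MTT assay, with a stated time of 3 days; on this read-out lower numbers stand for higher toxicity in this test and higher numbers for lower toxicity in this test. Compound 1, `CC[C@@H](CCn1cncn1)c1ccccc1`, and compound 2, `CC[C@H](CCn1cncn1)c1ccc(F)cc1`, share the same core. In this assay compound 1 gives 91.2 ug/mL. In this assay compound 2 gives 110 ug/mL, the highest of the two numbers, yet its nearest neighbour, compound 1, lies within the scatter, so the two cannot be told apart in this test. Compound 3, `CC[C@@H](CCn1cncn1)c1ccc(F)cc1`, comes next. Compared with compound 2 it shows (the two compounds have the same atoms and bonds and differ only in configuration as drawn: 1 of 1 stereo elements differ; a stereocentre at a saturated chain carbon is drawn R in compound 2 and S in compound 3). For the measured compounds named here, no step between two measured compounds that differ only at such a stereocentre is available, so there is nothing to show whether a change of configuration alone moves the number here. With that in mind, compound 3 is expected to sit close to compound 2, and the expected step, a 1.1-fold lower number from compound 2 to compound 3 (0.04 log units; within the scatter), stays within the scatter. The estimate for compound 3 is 100 ug/mL, with a range from 55 ug/mL to 180 ug/mL.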

Compound 3, half-maximal cytotoxic concentration: 91.6 ug/mL
Compound 3: middle estimate off by 1.1-fold (0.04 log units), on the high side; measured number inside the range.
By their numbers in this assay, from the lowest: compounds 1, 3 and 2 (each within the scatter of the next).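

In this assay, the change of configuration at the saturated chain carbon gives a 1.2-fold lower number from compound 2 to compound 3 (0.08 log units; within the scatter) and so has no effect that this test can detect for this pair, whether the stereocentre is drawn R or S. The comparison is a clean one, with a single structural difference to consider: the fact that compounds 2 and 3 differ only in the configuration as drawn. Fluoro in place of hydrogen on an aromatic carbon can now be read directly too, giving a 1.0-fold higher number from compound 1 to compound 3 (0.00 log units; within the scatter) and leaving that swap also within the scatter.

Still open, from the compounds shown here alone, is whether a different group at that aromatic carbon, such as an amine or a carboxylic acid, would move the number beyond the scatter. Also open, going by these compounds, is whether the configuration at the stereocentre would matter in a compound carrying such a group.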